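The source may report more compounds than this note shows. Statements on the series, on what has been measured and on what is new or still open speak of the compounds shown alone.

Compound 2 `CC#CCn1c(N2CCC[C@@H](N)C2)nc2c1c(=O)n(Cc1cccc(F)c1C(=O)OC)c(=O)n2C` is the starting point. In an ADME assay on isolated protein for inhibition of Dipeptidyl peptidase 9 (Homo sapiens), with stated times of 15 min, 60 s and 20 min (on this read-out lower numbers stand for stronger inhibition and higher numbers for weaker inhibition), compound 2 gives only a limit, > 100000 nM, and no number. Among the measured compounds shown here, its single neighbour in the set is compound 1 `CC#CCn1c(N2CCC[C@@H](N)C2)nc2c1c(=O)n(Cc1ccccc1C(=O)OC)c(=O)n2C`, which differs only by hydrogen in place of the fluoro on an aromatic carbon. In this assay compound 1 likewise gives a limit, > 100000 nM. The step that the two limits leave unreadable from compound 1 to compound 2 therefore cannot be read, since both ends rest on (the limit of > 100000 nM in this assay, at which 2 of the 2 values shown sit).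

Compound 3 `CC#CCn1c(N2CCC[C@@H](N)C2)nc2c1c(=O)n(Cc1ccc(F)cc1C(=O)O)c(=O)n2C` is not yet measured. It differs from compound 2 by 2-carboxy-4-fluorophenyl in place of 3-fluoro-2-(methoxycarbonyl)phenyl on a saturated chain carbon bound to an aromatic nitrogen. For the measured compounds named here, no measured step in this set touches either the ester-to-acid exchange or the moved fluoro, so there is no measured step that bears on this change directly; what the data show is only that compound 1 and compound 2 both sit at the same limit.

The expectation for compound 3 rests on that alone: a step of a number no higher from compound 2 to compound 3 (the limit leaves the size open) is estimated, without a readable precedent, and compound 3 is expected to give about 100000 nM, between 20000 nM and 500000 nM, with a strong chance that again only a limit is reported.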

Compound 3, half-maximal inhibitory concentration: > 100000 nM
Compound 3 gave a limit, no number (the forecaster's own chance of this, stated with the estimate: 80%); the middle value sits exactly at the limit.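

In this assay compound 3 gives only a limit, > 100000 nM. Among the compounds shown here, no step from compound 1 or compound 2 to compound 3 can be read, since each rests on limits at both ends: the limit of > 100000 nM in this assay, at which 3 of the 3 values shown sit. The compounds shown leave open how strongly any of the three inhibits the enzyme, and whether swapping these aryl groups changes that at all.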